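The compounds below may be only part of what the source reports. "The series", "measured", "known", "first", "only" and "open" are said of these compounds alone.

Measured so far in the series:
- compound 1, `C=C1/C=C/C(=O)/C(CO)=C\C[C@](C)(CCC=C(C)C)/C=C/[C@H]1OC(=O)C=C(C)C`: 2750 nM
- compound 2, `CC(C)=CCC[C@]1(C)/C=C/[C@@H](OC(=O)C=C(C)C)[C@](C)(O)/C=C/C(=O)/C(CCl)=C\C1`: 610 nM
- compound 3, `CC(C)=CCC[C@](C)(/C=C/[C@@H](OC(=O)C=C(C)C)[C@](C)(O)/C=C/C(=O)/C=C/N1CCN(C)CC1)CC=O`: 8840 nM

In a functional assay on MCF7 cells (Homo sapiens) for antiproliferative activity, read by MTT assay, with a stated time of 48 h (a lower number here means a stronger inhibitor, a higher number a weaker inhibitor), compound 2 gives the lowest of the three numbers, 610 nM. The nearest of the others is compound 1 at 2750 nM, a gap that lies beyond the scatter of the measurement. The furthest is compound 3 at 8840 nM, again beyond the scatter. No two of these three compounds differ in a single place, so no isolated step can be read from the measured set; each comparison mixes several changes at once.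

The next compound to be measured is compound 4, `CC(C)=CCC[C@]1(C)/C=C/[C@@H](OC(=O)C=C(C)C)[C@](C)(O)/C=C/C(=O)/C(C(=O)N2CCCC2)=C\C1`. Its relation to compound 2 is a single change: (pyrrolidin-1-yl)carbonyl in place of chloromethyl on a double-bonded ring carbon. Going by the values given here, the chloromethyl that leaves is present in compound 2 alone among the measured compounds, and compound 2 is the one with the lowest number. Compound 1 and compound 3, which carry other groups at related positions of their cores, both sit well higher. On that basis a weakening is expected for compound 4, beyond the scatter, as a step of a 4.9-fold higher number from compound 2 to compound 4 (0.69 log units; beyond the scatter). Among the compounds with values here, the estimate for compound 4 in this assay is 3000 nM, with a range from 800 nM to 12000 nM, the range kept wide since no measured pair shows this exact change.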

Compound 4, half-maximal inhibitory concentration: 17200 nM
The estimate for compound 4 lay 5.7-fold (0.76 log units) below the measured number; the measured number lies above the stated range.
By their numbers in this assay, from the lowest: compound 2; then compound 1; then compounds 3 and 4 (each within the scatter of the next).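

In this assay, going by these compounds alone, placing (pyrrolidin-1-yl)carbonyl in place of chloromethyl on the double-bonded ring carbon gives a 28-fold higher number from compound 2 to compound 4 (1.45 log units; beyond the scatter) as the one step that isolates a single place, and it is large and beyond the scatter. With the rest of the structure held constant, this ring carbon is therefore shown to be sensitive to the group it carries, which compound 1 and compound 3 could not show, since each differs from compound 2 in more than one place. The data at hand offer no measurement that explains the size of this step.

Because one step removes chloromethyl and introduces (pyrrolidin-1-yl)carbonyl together, the compounds shown cannot separate a loss tied to the departing group from a loss tied to the entering one. A plain methyl, a bromomethyl, a carboxylic acid or an open-chain dimethylamide at this same ring carbon of the shared core would bear on that question, and on whether compound 2 holds its place only with chloromethyl.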